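The compounds below may be only part of what the source reports. "The series", "measured", "known", "first", "only" and "open" are said of these compounds alone.

Working notes on the series. For the measured compounds named here, in a functional assay on HeLa cells (Homo sapiens) for cytotoxicity, read by sulforhodamine B assay, with a stated time of 72 h (a higher number here means a weaker inhibitor, a lower number a stronger inhibitor), compound 1 `COc1cc(NC(=O)/C=C/c2cccc(OC(F)(F)F)c2)cc(OC)c1OC` gives 4400 nM, the only numeric value so far. Compound 2 `COc1cc(NC(=O)/C=C/c2ccc(O)cc2)cc(OC)c1` is reported only as a limit of the assay, > 50000 nM. Compound 1 therefore has no numeric comparator, and no step size can be stated between the two.

Compound 3 `C#CCOc1cccc(/C=C/C(=O)Nc2cc(OC)c(OC)c(OC)c2)c1` has not yet been measured. It carries propargyl in place of trifluoromethyl on an oxygen on an aromatic ring, which reads as trifluoromethoxy to propargyloxy. Going by the values given here, no measured pair isolates this change, so the expectation in this assay is a loose one, anchored on compound 1 at 4400 nM. A modest shift toward weaker inhibition is expected, slightly beyond the usual scatter: a 1.8-fold higher number from compound 1 to compound 3 (0.26 log units; within the scatter). For compound 3 the estimated value is 8000 nM, with an expected range of 2500 nM to 30000 nM.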

Compound 3, half-maximal inhibitory concentration: 2000 nM
The estimate for compound 3 lay 4.0-fold (0.60 log units) above the measured number; the measured number lies below the stated range.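

In this assay, for the compounds shown here, the place on an oxygen on an aromatic ring accepts more than one group: going from trifluoromethoxy to propargyloxy gives a 2.2-fold lower number from compound 1 to compound 3 (0.34 log units; beyond the scatter) and provides the first numeric step. The step shows that activity at this place does not depend on keeping the fluorine atoms, as a group made only of carbon and hydrogen with a triple bond gives the lower number here. No result shown gives a cause for this step.

One pair cannot show whether the triple bond matters or whether any similar small group on this oxygen would do the same. A saturated propyl chain, a longer chain ending in an amine or a carboxylic acid at this place would test how far the change extends.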